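Carboxybutyl Chain in Place of a Tetrazolylpropoxy Chain

The compounds below may be only part of what the source reports. "The series", "measured", "known", "first", "only" and "open" are said of these compounds alone.

Compound 1, `CCCC(CCC(=O)O)Cc1cccc(OCc2ccc3ccccc3n2)c1`: 70 nM
Compound 2, `c1cc(OCCCc2nnn[nH]2)cc(OCc2ccc3ccccc3n2)c1`: 79 nM
Compound 3, `O=C(O)CC1(CCc2ccc(OCc3ccc4ccccc4n3)cc2)CCCC1`: 60 nM

Of the compounds shown here, three with a shared core have been measured in a functional assay (lung) for inhibition, with Cavia porcellus as the target; on this read-out lower numbers stand for stronger inhibition and higher numbers for weaker inhibition. Compound 2 gives the highest of the three numbers, but its gap to compound 1 and its gap to compound 3 both lie within the usual scatter, so none of the three can be called more or less potent than another.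

Compound 4 `O=C(O)CCCCc1cccc(OCc2ccc3ccccc3n2)c1` has not yet been measured. It differs from compound 2 in one place: 4-carboxybutyl in place of 3-(1H-tetrazol-5-yl)propoxy on an aromatic carbon. Going by the values given here, no measured pair in this set makes exactly this step, so any expectation must rest on what the three values show. Compound 1 likewise carries a carboxy group at the end of a chain on the same kind of ring, and in this assay compound 1 gives 70 nM, close to compound 2. Compound 4 is therefore expected to land near compound 2, with an expected step of a 1.5-fold higher number from compound 2 to compound 4 (0.18 log units; within the scatter) that stays within or only slightly beyond the scatter. The estimate for compound 4 is 120 nM, with a range from 40 nM to 400 nM.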

Compound 4, half-maximal inhibitory concentration: 370 nM
Estimate against measurement, compound 4: 3.1-fold (0.49 log units) below, and the stated range covers the measured number.
By their numbers in this assay, from the lowest: compounds 3, 1 and 2 (each within the scatter of the next); then compound 4.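

In this assay the chain on the aromatic carbon is no longer interchangeable: 4-carboxybutyl in place of 3-(1H-tetrazol-5-yl)propoxy gives a 4.7-fold higher number from compound 2 to compound 4 (0.67 log units; beyond the scatter) and so separates two chains that the earlier numbers could not tell apart. A carboxy group at the end of a chain is also not enough to keep the number low, since hydrogen in place of propyl on a saturated chain carbon bound to two saturated chain carbons gives a 5.3-fold higher number from compound 1 to compound 4 (0.72 log units; beyond the scatter) in the same read-out. No measurement shown here accounts for either step.

From the compounds shown here alone, it remains open whether a methyl or ethyl group on that chain carbon would be enough to give a number like that of compound 1. A longer chain ending in the same carboxylic acid also remains untested among the compounds shown.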